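A few compounds are considered here, and "the series" means these few. Any claim that something is new, unique, unknown or untested is made for them only; others in the source may bear on it.

In a functional assay on U-251 cells (Homo sapiens) for antiproliferative activity, read by MTT assay, with a stated time of 48 h (on this read-out lower numbers stand for stronger inhibition and higher numbers for weaker inhibition), compound 2 `COc1cc(-c2cccc3nc(-c4cccc(Br)c4)oc23)cc(OC)c1OC` gives 6800 nM. Compound 1 `COc1cccc(-c2nc3cccc(-c4cc(OC)c(OC)c(OC)c4)c3o2)c1` gives > 25000 nM, which is a limit of the assay. Compound 3 `COc1cc(-c2cccc3nc(-c4cccc(C)c4)oc23)cc(OC)c1OC` gives > 25000 nM, also a limit, and so stands at the limit of > 25000 nM in this assay, at which 2 of the 3 values shown sit. Compound 4 `COc1cc(-c2cccc3nc(-c4cccc(O)c4)oc23)cc(OC)c1OC` carries hydroxy in place of methyl on an aromatic carbon, meta to a large group: hydroxy in place of methyl on an aromatic carbon. The readable steps, an at least 3.6-fold lower number from compound 1 to compound 2 (0.56 log units; beyond the scatter) and an at least 3.6-fold higher number from compound 2 to compound 3 (0.56 log units; beyond the scatter), both turn on bromo, while a step that the two limits leave unreadable from compound 1 to compound 3 gives no size. Going by the values given here, no hydroxy compound has been measured, so given these steps, only a small move from the limit is expected, and compound 4 may stay there. The expected change is an at least 1.3-fold lower number from compound 3 to compound 4 (0.14 log units; that floor lies within the scatter). For compound 4 the estimated value is 18000 nM, with an expected range of 6000 nM to 40000 nM.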

Compound 4, half-maximal inhibitory concentration: 5500 nM
Compound 4: the middle estimate sits 3.3-fold (0.51 log units) above what was measured, and the stated range ends above it.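

Hydroxy in place of methyl on this aromatic carbon, meta to a large group, gives an at least 4.5-fold lower number from compound 3 to compound 4 (0.65 log units; beyond the scatter), so bromo is no longer the only group shown at this place to come off the limit. Hydroxy and bromo cannot be told apart here, with a 1.2-fold lower number from compound 2 to compound 4 (0.09 log units; within the scatter). Hydrogen in place of methyl on the oxygen gives an at least 4.5-fold lower number from compound 1 to compound 4 (0.65 log units; beyond the scatter), and both steps from a limit are floors rather than sizes: the limit of > 25000 nM in this assay, at which 2 of the 4 values shown sit.

Going by these compounds, whether an amine or a carboxylic acid at this place would also come off the limit remains open. So does whether hydroxy would do the same on another carbon of this ring.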